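The source may hold more compounds than are shown below. What is called first, only, known or untested is meant among the compounds shown, and "the series" means these compounds.

Compound 1 `CCc1ccc(-c2c(-c3ccc(C)cc3)n(Cc3ccc(OC)cc3)c3ccc([N+](=O)[O-])cc3c2=O)cc1`, 1660 nM in an assay on isolated protein for inhibition of alkaline phosphatase, tissue-nonspecific isozyme (Bos taurus), read by spectrophotometry, with stated times of 7 min and 15 min; a higher number here means a weaker inhibitor, a lower number a stronger inhibitor.
Compound 2 `COc1ccc(Cn2c(-c3ccc(C)cc3)c(-c3ccc(C(F)(F)F)cc3)c(=O)c3cc([N+](=O)[O-])ccc32)cc1`, 6190 nM in this assay.

Among the measured compounds shown here, of the two measured compounds, compound 2 gives the higher number, and so is the weaker inhibitor; the only step among them, a 3.7-fold higher number from compound 1 to compound 2 (0.57 log units; beyond the scatter), is a modest one. Compound 3 `COc1ccc(Cn2c(-c3ccc(C)cc3)c(C(F)(F)F)c(=O)c3cc([N+](=O)[O-])ccc32)cc1` is not yet measured. It differs from compound 2 in one place: trifluoromethyl in place of 4-(trifluoromethyl)phenyl on an aromatic carbon. For the measured compounds named here, no measured step bears on this change, since the step from compound 1 to compound 2 swapped one group for another on the pendant aromatic ring, whereas here the whole 4-(trifluoromethyl)phenyl group is removed and a trifluoromethyl left in its place. With nothing to lean on, the expectation for compound 3 is uncertain and is set near compound 2 with a wide range, estimated at 9000 nM (from 2000 nM to 40000 nM), which would mean an expected step of a 1.5-fold higher number from compound 2 to compound 3 (0.16 log units; within the scatter).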

Compound 3, half-maximal inhibitory concentration: 4530 nM
Compound 3: middle estimate off by 2.0-fold (0.30 log units), on the high side, and the stated range covers the measured number.
By their numbers in this assay, from the lowest: compound 1; then compounds 3 and 2 (each within the scatter of the next).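

Replacing 4-(trifluoromethyl)phenyl, with 10 heavy atoms, by trifluoromethyl, with 4, on the carbon two atoms from the ring nitrogen gives a 1.4-fold lower number from compound 2 to compound 3 (0.14 log units; within the scatter) in this assay, so at this position the change from compound 2 cannot be told from no change. Trifluoromethyl in place of 4-ethylphenyl gives a 2.7-fold higher number from compound 1 to compound 3 (0.44 log units; beyond the scatter) and is a real step, which shows that the outcome of removing the aromatic ring here depends on which ring group it replaces. No measurement at hand explains either result.

From the compounds shown here alone, it remains open whether an amine, a carboxylic acid or a longer alkyl chain on this carbon would give a lower number than these groups. Equally open, going by these compounds, is whether the lower number of compound 1 would hold with a methyl or a propyl in place of the ethyl on its ring.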